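Swapping a Nitrile for Bromine on a Sulfonyl Hydrazide

This account rests on a few compounds, and the source may have more. Where it says the series, first, only, none or still open, it means among the compounds named here.

Compound 1, `Cc1cccc(NNS(=O)(=O)c2ccc(C(=O)NCC(=O)O)cc2)c1`: in an assay on HeLa cells for inhibition of Indoleamine 2,3-dioxygenase 1 (Homo sapiens), read by spectrophotometry, with a stated time of 24 h (a higher number here means that more compound is needed for the effect, a lower number that less compound is needed), compound 1 gives 271 nM.
Compound 2, `CC(=O)Nc1ccc(S(=O)(=O)NNc2ccc(C#N)cc2)cc1`: in this assay compound 2 gives 1390 nM.

For the measured compounds named here, compound 2 holds the higher of the two numbers so far, meaning more of it is needed for the effect than of compound 1, and that gap is wider than the usual scatter of repeated measurements. Compound 3, `CC(=O)Nc1ccc(S(=O)(=O)NNc2ccc(Br)cc2)cc1`, is compound 2 with a single change: bromo in place of cyano on an aromatic carbon. Going by the values given here, no measured pair in this set shows that swap, so its effect cannot be read off directly. In this assay only a modest shift is expected, if any beyond the scatter, with a slight lean toward a lower number. Compound 3 is therefore estimated at 1000 nM, within a range from 300 nM to 3500 nM. That expectation corresponds to an estimated step of a 1.4-fold lower number from compound 2 to compound 3 (0.14 log units; within the scatter).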

Compound 3, half-maximal effective concentration: 85 nM
The estimate for compound 3 lay 12-fold (1.07 log units) above the measured number; the whole stated range lies above it.
By their numbers in this assay, from the lowest: compound 3; then compound 1; then compound 2.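

In this assay, the group on this aromatic carbon, para to a large group, turns out to matter a great deal: bromo in place of cyano gives a 16-fold lower number from compound 2 to compound 3 (1.21 log units; beyond the scatter). The gap between compound 1 and compound 2 involved differences in more than one place, whereas this pair changes one group and leaves the rest of the structure the same. Nothing available explains why this single swap produces a step of this size.

On these data alone, how a chloro group or an amine at this same position would compare remains open. Also open, as far as these compounds go, is whether bromo in place of cyano would bring a similar step in a compound with a different group on the other aromatic ring, such as a carboxylic acid chain.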